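A few compounds are considered here, and "the series" means these few. Any claim that something is new, unique, unknown or untested is made for them only; others in the source may bear on it.

Measured so far in a functional assay on DLD-1 cells (Homo sapiens), read by microscopy and crystal violet staining, with a stated time of 20 h, tested at 10 ug/mL; on this read-out higher numbers stand for more inhibition at the one concentration tested (going by the name of the read-out) and lower numbers for less inhibition:
- compound 1 `O=C1NC(=S)S/C1=C\C=C\c1ccccc1OCc1ccccc1C(F)(F)F`: compound 1 gives 80%
- compound 2 `COc1ccccc1COc1ccccc1/C=C/C=C1\SC(=S)NC1=O`: compound 2 gives 98%
- compound 3 `O=C1NC(=S)S/C1=C\c1cc(Br)ccc1OCc1ccccc1Br`: compound 3 gives 95%

Compound 2 stands highest of the three numbers. Its gap to compound 3 lies within the scatter, so no order between the two is claimed; its gap to compound 1 lies beyond the scatter, and that single-point step, a number 18 percentage points higher from compound 1 to compound 2 (beyond the scatter), is modest.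

Compound 4 `COc1ccccc1/C=C/C=C1\SC(=S)NC1=O` has not yet been measured. It differs from compound 2 by hydrogen in place of 2-methoxyphenyl on a saturated chain carbon bound to an oxygen on an aromatic ring. Within the data shown here, no measured step bears directly on this change: the one step available compares methoxy against trifluoromethyl on the aromatic carbon of a group that here leaves altogether, and compound 3 differs from compound 2 in more than one place. Among the measured compounds shown here, all three measured compounds carry an aromatic ring on that saturated chain carbon; compound 4 is the first without one, so the expectation is uncertain and leans toward a decrease beyond the scatter. Compound 4 is therefore expected to give 65%, within 30% to 95%. That estimate means an expected step of a number 33 percentage points lower from compound 2 to compound 4 (beyond the scatter).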

Compound 4, a percentage reported as inhibition, at one concentration (the size of the read-out at that concentration, not a potency): 69%
Beside the measured number, compound 4's estimate is 4 percentage points below it; measured number inside the range.
By their numbers in this assay, from the lowest: compound 4; then compound 1; then compounds 3 and 2 (each within the scatter of the next).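

In this assay, hydrogen in place of 2-methoxyphenyl on a saturated chain carbon bound to an oxygen on an aromatic ring gives a number 29 percentage points lower from compound 2 to compound 4 (beyond the scatter), so the read-out at this position depends on what the chain carbon carries. The dependence is partial: without the ring, compound 4 still gives 69%, so 2-methoxyphenyl is not needed for inhibition at the one concentration tested. Nothing at hand explains the size of this step.

The compounds shown do not separate the part played by the aromatic ring from that of the methoxy on it, which an unsubstituted phenyl at this place would address. From the compounds shown here alone, whether a non-aromatic group such as cyclohexyl or a longer chain could take the place of the ring also remains open.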